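A few compounds are considered here, and "the series" means these few. Any claim that something is new, unique, unknown or untested is made for them only; others in the source may bear on it.

In an ADME assay on cells (Erythrocyte, Homo sapiens), read by spectrophotometry and hemolysis, with a stated time of 24 h (a lower number here means a stronger inhibitor, a higher number a weaker inhibitor), the record for this series is thin. Compound 1 `CC1(C)[N+]([O-])=c2ccc(COc3ccc(/C=N/NC(N)=S)cc3)cc2=[N+]1[O-]` returned "nd(insoluble)" (no result reported). Compound 3 `C=CCNC(=S)N/N=C\c1ccccc1OCc1ccc2c(c1)=[N+]([O-])C(C)(C)[N+]=2[O-]` returned "nd(insoluble)" (no result reported), so compound 3 stands without a number of its own. Compound 2 `CC1(C)[N+]([O-])=c2ccc(COc3ccccc3/C=N\NC(N)=S)cc2=[N+]1[O-]` gave > 200 uM, which is a limit of the assay and not a number. Compound 4 `CC1(C)[N+]([O-])=c2ccc(COc3ccccc3/C=N\NC(N)=O)cc2=[N+]1[O-]` has yet to be measured. The structural change is a group of 3 heavy atoms (1 carbon, 1 nitrogen, 1 oxygen; no ring) in place of a group of 6 heavy atoms (4 carbon, 1 nitrogen, 1 sulfur; no ring), on an amine nitrogen: carbamoyl enters on an amine nitrogen, in place of a group of 6 heavy atoms with no ring. Among the compounds with values here, no measured step exists to show what such a change does, and compound 3 offers no number to step from. Within the data shown here, the only guide is the limit that compound 2 shows, > 200 uM. The expectation in this assay is therefore for no step beyond the usual scatter from that limit, in either direction. For compound 4 the estimated value is 250 uM, with an expected range from 100 uM to 500 uM.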

Compound 4, concentration for 50% inhibition: 50 uM
Estimate against measurement, compound 4: 5.0-fold (0.70 log units) above, outside the stated range (below it).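

In this assay, carbamoyl in place of the group of one carbon, one nitrogen and one sulfur, on an amine nitrogen whose other neighbour is a double-bonded nitrogen, gives an at least 4.0-fold lower number from compound 2 to compound 4 (0.60 log units; beyond the scatter). Compound 2 stands at a limit of the assay and not at a number: the limit of > 200 uM in this assay, at which 1 of the 4 values shown sits. Compound 4, at 50 uM, holds the only single number among the compounds shown, so the series now shows that the reading at this position responds to a change of one atom, oxygen for sulfur, which the earlier compounds could not show.

On these data alone, the full size of the step stays unknown, and any step involving compound 1 or compound 3 cannot be read. As far as these compounds go, whether an acetyl group or a longer chain on that amine nitrogen would move the number further also remains open.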